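Methyl in Place of Fluoro on an Aryl Piperazine

This account rests on a few compounds, and the source may have more. Where it says the series, first, only, none or still open, it means among the compounds named here.

Compound 1 `CCCc1nc(-c2ccccc2)c(CNCCCN2CCN(c3ccc(F)cc3)CC2)o1` has the higher number of the two compounds measured in an assay on HEK293 cells for inhibition of Voltage-dependent T-type calcium channel subunit alpha-1G (Homo sapiens), read by fluorescence, tested at 10 uM; a lower number here means less inhibition, a higher number more inhibition at the concentration tested (going by the name of the read-out). Compound 1 gives 62.5%, while compound 2 `CCCc1nc(-c2ccccc2)c(CNCCN2CCN(c3ccccn3)CC2)o1` gives 48.1%, a gap that exceeds the scatter. Compound 3 `CCCc1nc(-c2ccccc2)c(CNCCCN2CCN(c3ccc(C)cc3)CC2)o1` is not yet measured. It differs from compound 1 by methyl in place of fluoro on an aromatic carbon. Going by the values given here, since no step between measured compounds matches this change, the step from compound 1 to compound 3 is expected to be small, likely within the scatter, as a number 2.5 percentage points lower from compound 1 to compound 3 (within the scatter). Compound 3 is thus estimated at 60%, with a range from 42% to 78%.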

Compound 3, a percentage reported as inhibition, at one concentration (the size of the read-out at that concentration, not a potency): 53.9%
Estimate against measurement, compound 3: 6.1 percentage points above; measured number inside the range.
By their numbers in this assay, from the lowest: compounds 2, 3 and 1 (each within the scatter of the next, the first and the last beyond it).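

In this assay, methyl in place of fluoro on the aromatic carbon para to a large group gives a number 8.6 percentage points lower from compound 1 to compound 3 (within the scatter), so the change from 4-fluorophenyl to 4-methylphenyl leaves the read-out within its scatter. Going by these compounds alone, this is the first step that changes a single place, which compound 2 could not offer. No measured property of either group bears on this result. Going by these compounds, it remains open whether a methoxy group, a chlorine atom or an amine at this position would also stay within the scatter of compound 1. The compounds shown also do not tell how a longer chain would read at the same position.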